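Thioester to amide on the coumarin-like core: compound 3 to 4

The source may report more compounds than this note shows. Statements on the series, on what has been measured and on what is new or still open speak of the compounds shown alone.

Compound 3 `CC(=O)OCc1ccc2oc(=O)c(C(=O)Sc3cccc(Br)c3)cc2c1` sits among three measured compounds. In a functional assay on HT-1080 cells (Homo sapiens), read by transwell migration, with a stated time of 24 h, tested at 1 uM (a higher number here means a weaker effect of the compound at the concentration tested, a lower number a stronger effect), compound 3 gives 70.9%, the second highest of the three numbers. Its nearest neighbour is compound 2 `CC(=O)OCc1ccc2oc(=O)c(C(=O)Sc3cccc(Cl)c3)cc2c1`, which gives 65.8%, and the step of a number 5.1 percentage points higher from compound 2 to compound 3 (within the scatter) lies within the scatter. Furthest away is compound 1 `CC(=O)OCc1ccc2oc(=O)c(C(=O)Sc3ccccc3)cc2c1`, which gives 83.5%; the steps of a number 17.7 percentage points lower from compound 1 to compound 2 (beyond the scatter) and a number 12.6 percentage points lower from compound 1 to compound 3 (beyond the scatter) are both beyond the scatter, so either halogen on the aromatic carbon lowers the number compared with hydrogen.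

Compound 4 `CC(=O)OCc1ccc2oc(=O)c(C(=O)Nc3cccc(Cl)c3)cc2c1` has not been measured. It differs from compound 3 in one place: (3-chlorophenyl)amino in place of (3-bromophenyl)sulfanyl on a carbonyl carbon. Two things change at once, the halogen and the atom joining the carbonyl carbon to the ring. For the halogen part the step of a number 5.1 percentage points higher from compound 2 to compound 3 (within the scatter) is the relevant precedent, and it was within the scatter. For the exchange of the sulfanyl link for an amino link there is no measured step among these compounds, so no direction can be read from the data.

The author therefore expects the step of a number 2.9 percentage points lower from compound 3 to compound 4 (within the scatter) to be small, with no clear direction beyond the scatter. For compound 4 the estimate in this assay is 68%, ranging from 50% to 86%.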

Compound 4, a percentage reported as activity, at one concentration (the size of the read-out at that concentration, not a potency): 66.9%
For compound 4 the middle estimate is 1.1 percentage points above the measured one; low and high end bracket the measured number.
By their numbers in this assay, from the lowest: compounds 2, 4 and 3 (each within the scatter of the next); then compound 1.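

Among the compounds shown here, the exchange of the sulfanyl link for an amino link, which no earlier pair could show, can now be read on its own: with the chlorine held in place, a number 1.1 percentage points higher from compound 2 to compound 4 (within the scatter) in this assay lies within the scatter, so on this carbonyl carbon the amino link serves as well as the sulfanyl link in these compounds. The double change also stays within the scatter, as a number 4 percentage points lower from compound 3 to compound 4 (within the scatter) shows, while a number 16.6 percentage points lower from compound 1 to compound 4 (beyond the scatter) lies beyond it and places the amino compound with the two halogenated thioesters rather than with the unsubstituted phenylsulfanyl compound. Nothing given here explains why the two links read alike.

Going by these compounds, it remains open whether a plain phenylamino group would sit as far above the chlorinated amino compound as the phenylsulfanyl group does above its halogenated partners, which would tell whether the halogen matters in the same way with either link. On these data alone, how a phenoxy group or a longer chain such as benzylamino would read on this carbonyl carbon also remains open.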